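Replacing the 2,3,4-trifluorophenyl group of compound 2

The source may hold more compounds than are shown below. What is called first, only, known or untested is meant among the compounds shown, and "the series" means these compounds.

In a functional assay on CCRF-CEM cells (Homo sapiens) for antiproliferative activity, with a stated time of 72 h (on this read-out lower numbers stand for stronger inhibition and higher numbers for weaker inhibition), compound 1 `OC[C@H]1O[C@@H](n2cnc3c(NCc4cccc(Br)c4)ncnc32)[C@H](O)[C@@H]1O` gives 5000 nM and compound 2 `OC[C@H]1O[C@@H](n2cnc3c(NCc4ccc(F)c(F)c4F)ncnc32)[C@H](O)[C@@H]1O` gives 58200 nM, the higher of the two numbers and so the weaker inhibition. Compound 3 `OC[C@H]1O[C@@H](n2cnc3c(NCc4ccc(F)cc4Cl)ncnc32)[C@H](O)[C@@H]1O` is unmeasured: it carries 2-chloro-4-fluorophenyl in place of 2,3,4-trifluorophenyl on a saturated chain carbon bound to a nitrogen on an aromatic ring, (2-chloro-4-fluorophenyl in place of 2,3,4-trifluorophenyl on a saturated chain carbon bound to a nitrogen on an aromatic ring). For the measured compounds named here, the only measured step at this place is a 12-fold higher number from compound 1 to compound 2 (1.07 log units; beyond the scatter), so a change here can be large. A moderate move toward lower numbers is expected, a 3.6-fold lower number from compound 2 to compound 3 (0.56 log units; beyond the scatter). For compound 3 the estimate is 16000 nM, with an expected range of 4000 nM to 60000 nM.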

Compound 3, half-maximal inhibitory concentration: 20900 nM
Compound 3: middle estimate off by 1.3-fold (0.12 log units), on the low side; measured number inside the range.
By their numbers in this assay, from the lowest: compound 1; then compound 3; then compound 2.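

In this assay, the halogen pattern on this phenyl group matters in more than one direction. The 2-chloro-4-fluorophenyl group gives a 2.8-fold lower number from compound 2 to compound 3 (0.44 log units; beyond the scatter) when it replaces 2,3,4-trifluorophenyl, but it still falls short of 3-bromophenyl, with a 4.2-fold higher number from compound 1 to compound 3 (0.62 log units; beyond the scatter) as the step between those two groups. Nothing measured here explains these differences.

From the compounds shown here alone, all three groups carry only halogens on the phenyl ring, so the effect of a methoxy group or an amine there remains open. It is also unclear which halogen of compound 3 accounts for its step from compound 2.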